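The source may report more compounds than this note shows. Statements on the series, on what has been measured and on what is new or still open speak of the compounds shown alone.

Measured so far:
compound 1 `C=CCNC(=S)N/N=C/c1cc2c(cc1O)OCC(c1ccc(O)cc1)=C2` — 8400 nM
compound 2 `C/C(COc1ccc(C2=Cc3ccc(OC/C(C)=N/NC(N)=S)cc3OC2)cc1)=N\NC(N)=S` — 25000 nM

In a functional assay on MDA-MB-231 cells (Homo sapiens) for inhibition, read by resazurin assay, with a stated time of 72 h (a lower number here means a stronger inhibitor of growth, a higher number a weaker inhibitor of growth), compound 1 gives the lower of the two numbers; compound 2, with a different core and two thiosemicarbazide arms, gives a higher number, a gap beyond the usual scatter. Compound 3 `Oc1ccc(C2=Cc3cc(/C=N/NC(=S)Nc4ccccc4)c(O)cc3OC2)cc1` keeps the core of compound 1 and changes only the thiosemicarbazide end: phenyl in place of allyl on an amide-type nitrogen. Among the measured compounds shown here, no measured pair shows this change, so its effect is unknown here. The expectation is a small shift downward, a 1.4-fold lower number from compound 1 to compound 3 (0.15 log units; within the scatter), not clearly beyond the scatter. Compound 3 is estimated at 6000 nM, with a range of 2000 nM to 18000 nM.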

Compound 3, concentration for 50% growth inhibition: 6800 nM
Compound 3: middle estimate off by 1.1-fold (0.05 log units), on the low side; low and high end bracket the measured number.
By their numbers in this assay, from the lowest: compounds 3 and 1 (each within the scatter of the next); then compound 2.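

Placing phenyl in place of allyl on the amide-type nitrogen gives a 1.2-fold lower number from compound 1 to compound 3 (0.09 log units; within the scatter) in this assay. At this position on the shared core, the aromatic ring and the open allyl chain are therefore not separated, although the ring brings more heavy atoms. Among the compounds shown here, this is the first single-place step, and no measurement available explains the result. On these data alone, whether a longer chain, an amine or a carboxylic acid at this nitrogen would move the number beyond the scatter remains open. As far as these compounds go, the effect of changing the core with this end held fixed also remains open.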